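Swapping Fluoro for Iodo in Compound 3

A few compounds are considered here, and "the series" means these few. Any claim that something is new, unique, unknown or untested is made for them only; others in the source may bear on it.

Compound 1 `O=C(CCc1cccc2c1B(O)OC2)NC1CCCCC1` gives > 100000 nM, a limit
Compound 2 `O=C(CCc1cccc2c1B(O)OC2)NCc1ccccc1` gives > 100000 nM, a limit
Compound 3 `O=C(CCc1cccc2c1B(O)OC2)Nc1ccc(F)cc1` gives 650 nM

Within the data shown here, these results come from a functional assay on HCT-116 cells (Homo sapiens) for antiproliferative activity, read by MTT assay, with a stated time of 72 h (on this read-out lower numbers stand for stronger inhibition and higher numbers for weaker inhibition), and leave compound 3 as the only member of the series with an actual number. The entries for compound 1 and compound 2 are limits, and the shared ceiling is the limit of > 100000 nM in this assay, at which 2 of the 3 values shown sit.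

Compound 4 `O=C(CCc1cccc2c1B(O)OC2)Nc1ccc(I)cc1` keeps the shared core and the amide but has iodo in place of fluoro on an aromatic carbon, para to a large group: iodo in place of fluoro on an aromatic carbon.

Two large measured steps lead to compound 3: an at least 150-fold lower number from compound 1 to compound 3 (2.18 log units; beyond the scatter) and an at least 150-fold lower number from compound 2 to compound 3 (2.18 log units; beyond the scatter). A third, a step that the two limits leave unreadable from compound 1 to compound 2, gives no size. The first two replace the whole group on the amide nitrogen, so they bear on the new change only indirectly. Compound 4 retains the aromatic ring carried by compound 3 at 650 nM, so no large step is expected, and no shift beyond the scatter is predicted in either direction.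

The expected change is a 1.3-fold lower number from compound 3 to compound 4 (0.11 log units; within the scatter).

For compound 4 the estimated value in this assay is 500 nM, with an expected range from 120 nM to 2500 nM.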

Compound 4, half-maximal inhibitory concentration: 50000 nM
Compound 4: middle estimate off by 100-fold (2.00 log units), on the low side, and the stated range ends below it.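

In this assay, the earlier compounds had shown large shifts only when the whole group on the amide nitrogen was replaced, whereas here the exchange of a single atom on an aromatic carbon, para to a large group, gives a 77-fold higher number from compound 3 to compound 4 (1.89 log units; beyond the scatter). Keeping the aromatic ring therefore does not preserve the number seen with the 4-fluorophenyl group, and the identity of the halogen at this position carries much of the difference. The 4-iodophenyl group also separates only weakly from the other two amide groups, with an at least 2.0-fold lower number from compound 2 to compound 4 (0.30 log units; that floor lies within the scatter) and an at least 2.0-fold lower number from compound 1 to compound 4 (0.30 log units; that floor lies within the scatter), and both of these floors are set by an assay ceiling rather than by actual numbers for the other two compounds: the limit of > 100000 nM in this assay, at which 2 of the 4 values shown sit.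

The compounds shown leave open how chloro, bromo or a methyl group at this same place would read, and so whether the shift builds gradually or belongs to iodo alone. They also leave open whether a plain phenyl group on the amide nitrogen would read nearer compound 3 or compound 4.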